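Chloro for bromo on the indole of compound 2

The source may report more compounds than this note shows. Statements on the series, on what has been measured and on what is new or still open speak of the compounds shown alone.

In a functional assay on A549 cells (Homo sapiens) for inhibition, read by sulforhodamine B assay, with a stated time of 48 h (a higher number here means a weaker inhibitor of growth, a lower number a stronger inhibitor of growth), compound 1 `COC(=O)[C@@]1(C)CCC=C2[C@@H]1CC[C@@H](C)[C@]2(C)Cc1c[nH]c2ccc(Cl)cc12` gives 16000 nM and compound 2 `COC(=O)[C@@]1(C)CCC=C2[C@@H]1CC[C@@H](C)[C@]2(C)Cc1c(C)[nH]c2ccc(Br)cc12` gives 15000 nM; in this assay the two numbers lie within the scatter of each other, so compound 2 does not stand apart from compound 1. Compound 3 `COC(=O)[C@@]1(C)CCC=C2[C@@H]1CC[C@@H](C)[C@]2(C)Cc1c(C)[nH]c2ccc(Cl)cc12` differs from compound 2 only by chloro in place of bromo on an aromatic carbon. Among the compounds with values here, no measured pair shows this exchange alone, and with compound 1 at 16000 nM already carrying chloro, no step beyond the scatter is expected in this assay. For compound 3 the estimate is 16000 nM, between 8000 nM and 32000 nM, which means an expected step of a 1.1-fold higher number from compound 2 to compound 3 (0.03 log units; within the scatter).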

Compound 3, concentration for 50% growth inhibition: 17000 nM
Compound 3: the middle estimate sits 1.1-fold (0.03 log units) below what was measured; the range from low to high includes it.
By their numbers in this assay, from the lowest: compounds 2, 1 and 3 (each within the scatter of the next).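

In this assay, within the data shown here, chloro in place of bromo on the aromatic carbon gives a 1.1-fold higher number from compound 2 to compound 3 (0.05 log units; within the scatter) and so, read alone for the first time, this exchange does not separate the two compounds. Methyl in place of hydrogen on an aromatic carbon gives a 1.1-fold higher number from compound 1 to compound 3 (0.03 log units; within the scatter) and likewise stays within the scatter, so neither of the two places responds to these small changes. No measurement bearing on these results is available.

On these data alone, whether an amine or a carboxylic acid in place of the halogen would leave the number where it stands remains open. The same holds for a longer chain in place of the methyl, read in this assay against compound 3.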